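Fluoro for cyano on the aryl of compound 1

This account rests on a few compounds, and the source may have more. Where it says the series, first, only, none or still open, it means among the compounds named here.

Working notes on a small set of amides measured in an in vitro functional assay on 1321-N1 cells for antagonist activity at transient receptor potential cation channel subfamily V member 1 (Homo sapiens), read by FLIPR and calcium flux; a higher number here means a more potent compound, by a factor of ten per unit of this negative logarithm, a lower number a less potent compound. Compound 1 `N#Cc1ccc(-c2ccc(C(=O)Nc3ccc4cccnc4c3)cn2)cc1` gives only a limit in this assay, < 6.6, so its standing on the numbers is a ceiling rather than a point. Compound 2 `Cc1nc(-c2ccc(F)cc2)ccc1C(=O)Nc1ccc2ccn(C)c2c1` likewise gives only a limit in this assay, < 6.5. Going by the values given here, compound 3 `Cc1nc(-c2ccc(F)cc2)ccc1C(=O)Nc1ccc2cn[nH]c2c1` is the one member with a measured number, 7.5 in this assay. The two limits are recorded at the limit of < 6.5 in this assay, at which 1 of the 3 values shown sits, and at the limit of < 6.6 in this assay, at which 1 of the 3 values shown sits.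

Compound 4 `O=C(Nc1ccc2cccnc2c1)c1ccc(-c2ccc(F)cc2)nc1` is not yet measured. It differs from compound 1 by fluoro in place of cyano on an aromatic carbon, placed on an aromatic carbon of a six-membered aromatic ring of carbon only, para to a large group. Among the compounds with values here, no measured pair in the set shows this same change, so no step size can be read off. Since compound 1 sits at a limit, the expected step is written as a step that the limit leaves unreadable from compound 1 to compound 4, with little confidence in its direction. Compound 4 is estimated at 6.4 in this assay, within 5.4 to 7.4, and a further limit is a real possibility.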

Compound 4, negative logarithm of the antagonist equilibrium constant: 8.2
Beside the measured number, compound 4's estimate is 1.80 log units below it; the measured number lies above the stated range.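

In this assay compound 1 gives < 6.6, which is a limit of the assay and not a number. Going by these compounds alone, on an aromatic carbon para to a large group, the change from 4-cyanophenyl to 4-fluorophenyl gives a number at least 1.60 log units higher from compound 1 to compound 4 (beyond the scatter), the first step in the set that can be read and evidence that the core of compound 1 responds strongly to the group at this place. The size of the step is only a lower bound, because compound 1 stands at a limit: the limit of < 6.6 in this assay, at which 1 of the 4 values shown sits.

With only nitrile and fluoro seen at this place, the compounds shown cannot tell whether the step comes from gaining fluoro or from losing the nitrile. On these data alone, how a chloro, a methoxy or a plain hydrogen would read in this assay remains open, as does whether the same change carries over to the cores of compound 2 and compound 3.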